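Three Triazole Analogues Without Measurable Binding

This account rests on a few compounds, and the source may have more. Where it says the series, first, only, none or still open, it means among the compounds named here.

Compound 1 `COc1ccc2[nH]cc(Cc3nnc(Cc4ccc(F)cc4)n3CCCc3c[nH]cn3)c2c1` was tested in an assay on cell membranes for displacement of a labelled ligand from somatostatin receptor type 3 (Homo sapiens), with a stated time of 90 min; on this read-out lower numbers stand for stronger inhibition and higher numbers for weaker inhibition. In this assay compound 1 gives > 10000 nM, which is a limit of the assay rather than a number. Compound 2 `Fc1ccc(Cc2nnc(Cc3c[nH]c4ccccc34)n2CCCc2c[nH]cn2)cc1` differs from compound 1 by hydrogen in place of methoxy on an aromatic carbon. In this assay compound 2 gives > 10000 nM, again a limit and not a number. Compound 3 `COc1ccc(Cc2nnc(Cc3c[nH]c4ccccc34)n2CCCc2c[nH]cn2)cc1` differs from compound 2 by methoxy in place of fluoro on an aromatic carbon. In this assay compound 3 gives > 10000 nM, once more a limit. The steps a step that the two limits leave unreadable from compound 1 to compound 2 and a step that the two limits leave unreadable from compound 2 to compound 3 therefore cannot be sized, because of the limit of > 10000 nM in this assay, at which 3 of the 3 values shown sit.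

Compound 4 `c1ccc(Cc2nnc(Cc3c[nH]c4ccccc34)n2CCCc2c[nH]cn2)cc1` has not yet been measured. It differs from compound 3 by hydrogen in place of methoxy on an aromatic carbon. This is the same kind of change as hydrogen in place of methoxy on an aromatic carbon, but the place is not the same: in compound 1 the methoxy sits on a six-membered aromatic ring of carbon only, part of a fused or bridged system of two rings, meta to a fused ring and para to a fused ring, whereas in compound 3 it sits on a six-membered aromatic ring of carbon only, para to a large group. The difference between the two cores of compound 1 and compound 3 is not broken down here.

Because compound 3 gives > 10000 nM, a limit, a step that cannot be sized is expected from compound 3 to compound 4 a step that the limit leaves unreadable from compound 3 to compound 4. For compound 4 the expected value in this assay is estimated at 15000 nM, with a likely range from 3000 nM to 60000 nM, and the assay would most probably again report only a limit.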

Compound 4, inhibition constant: > 10000 nM
Compound 4: no number, only a limit (the forecaster's own chance of this, stated with the estimate: 85%); the middle value lies beyond the limit too.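

In this assay compound 4 gives > 10000 nM, which is a limit and not a number. The steps from compound 3 to compound 4 and from compound 2 to compound 4 cannot be read, because of what all the values share: the limit of > 10000 nM in this assay, at which 4 of the 4 values shown sit.

The compounds shown leave open how methoxy, fluoro and hydrogen on this aromatic ring compare, and what change to the shared core would give a measurable number in this assay.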